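Piperazine substituent swap in the aminomethyl series

A few compounds are considered here, and "the series" means these few. Any claim that something is new, unique, unknown or untested is made for them only; others in the source may bear on it.

Working notes on a small set of compounds that share a bicyclic amine core bearing a piperazine on its aromatic ring. Compound 1 `CN(C[C@H]1Cc2c(cccc2N2CCN(C3CC3)CC2)CN1)[C@H]1CCCc2cccnc21` carries a cyclopropyl on the piperazine amine nitrogen. Compound 2 `Cc1cnc2c(c1)CCC[C@@H]2N(C)C[C@H]1Cc2c(cccc2N2CCNCC2)CN1` carries an unsubstituted piperazine and a methyl on the pyridine-containing portion.

In a functional assay on CCRF-CEM cells for agonist activity at C-X-C chemokine receptor type 4 (Homo sapiens), read by calcium flux, with a stated time of 25 min (a higher number here means that more compound is needed for the effect, a lower number that less compound is needed), compound 1 gives > 30000 nM, which is a limit of the assay and not a number. In this assay compound 2 likewise gives > 30000 nM, again only a limit. Both values sit at the limit of > 30000 nM in this assay, at which 2 of the 2 values shown sit, so no ranking between compound 1 and compound 2 is possible; compound 1 stands only at the limit.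

Compound 3 `CN(C[C@H]1Cc2c(cccc2N2CCN(c3cccc(C(F)(F)F)c3)CC2)CN1)[C@H]1CCCc2cccnc21` is not yet measured. The change from compound 1 to compound 3 is 3-(trifluoromethyl)phenyl in place of cyclopropyl on an amine nitrogen in a ring. For the measured compounds named here, with no measured step in the set to lean on, the expectation is no change beyond the scatter: compound 3 is expected to remain at the limit, the step from compound 1 to compound 3 being estimated as a step that the limit leaves unreadable from compound 1 to compound 3. For compound 3 the estimated value in this assay is 40000 nM, within 8000 nM to 200000 nM.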

Compound 3, half-maximal effective concentration: > 30000 nM
Compound 3 ended at the assay's limit (the forecaster's own chance of this, stated with the estimate: 80%); the middle value lies beyond the limit too.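

With compound 3 also at a limit, no size can be read for the swap of cyclopropyl for 3-(trifluoromethyl)phenyl between compound 1 and compound 3, because all the values stand at the same limit: the limit of > 30000 nM in this assay, at which 3 of the 3 values shown sit.

The compounds shown leave open which change to the piperazine substituent or the shared core, if any, would give a readable value in this assay.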